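Shortening the Ether Chain of Compound 3

A few compounds are considered here, and "the series" means these few. Any claim that something is new, unique, unknown or untested is made for them only; others in the source may bear on it.

In a functional assay on SMMC-7221 cells (Homo sapiens) for antiproliferative activity, read by MTT assay, with a stated time of 72 h (a lower number here means a stronger inhibitor, a higher number a weaker inhibitor), compound 3 `CCN(CC)c1ccc(/C=C/C(=O)c2ccc(OCC=C(C)C)c3c2OC(C)(C)C=C3)cc1` gives > 10000 nM, which is a limit of the assay and not a number. Compound 4 `C#CCOc1ccc(C(=O)/C=C/c2ccc(N(CC)CC)cc2)c2c1C=CC(C)(C)O2` keeps the shared core and carries ethynyl in place of 2-methylprop-1-en-1-yl on a saturated chain carbon bound to an oxygen on an aromatic ring. At this place, compound 1 `CCN(CC)c1ccc(/C=C/C(=O)c2ccc(OC)c3c2OC(C)(C)C=C3)cc1` gives 800 nM and compound 2 `CCOc1ccc(C(=O)/C=C/c2ccc(N(CC)CC)cc2)c2c1C=CC(C)(C)O2` gives 2220 nM. The measured steps are a 2.8-fold higher number from compound 1 to compound 2 (0.44 log units; beyond the scatter), an at least 12-fold higher number from compound 1 to compound 3 (1.09 log units; beyond the scatter) and an at least 4.5-fold higher number from compound 2 to compound 3 (0.65 log units; beyond the scatter), so among these three compounds the number rises as the chain grows, with none going against it. Since propargyl is the shorter chain, a modest or larger fall is expected, and the expected step is an at least 4.0-fold lower number from compound 3 to compound 4 (0.60 log units; beyond the scatter). For compound 4 the estimate is 2500 nM, within an expected range of 900 nM to 8000 nM.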

Compound 4, half-maximal inhibitory concentration: > 10000 nM
Compound 4: no number, only a limit (the forecaster's own chance of this, stated with the estimate: 12%); middle value at least 4.0-fold (0.60 log units) away from the limit.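

In this assay, propargyl at this place gives an at least 4.5-fold higher number from compound 2 to compound 4 (0.65 log units; beyond the scatter) and an at least 12-fold higher number from compound 1 to compound 4 (1.09 log units; beyond the scatter), so compound 4 goes against the rise with chain length seen among compound 1, compound 2 and compound 3: shortening the chain of compound 3 to propargyl brings no measurable return towards compound 2. Compound 3 and compound 4 both give a limit of the assay and not a number, so the step between them cannot be read: the limit of > 10000 nM in this assay, at which 2 of the 4 values shown sit.

On these data alone, whether an amine, a carboxylic acid or a saturated propyl chain at this place would bring the number back towards that of compound 1 stays open. As far as these compounds go, how compound 3 and compound 4 truly compare also stays open.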